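Aryl variation on the ring amide nitrogen of the shared core

This account rests on a few compounds, and the source may have more. Where it says the series, first, only, none or still open, it means among the compounds named here.

Measured compounds:
- compound 1, `CC(C)[C@@H]1CC[C@@H](C)C[C@@]12N(C)C(=O)[C@@H]1[C@H]3C(=O)N(c4ccc(Cl)cc4)C(=O)[C@H]3ON12`: 2150 ug/mL
- compound 2, `Cc1cccc(N2C(=O)[C@H]3[C@H](ON4[C@@H]3C(=O)N(C)[C@@]43C[C@H](C)CC[C@H]3C(C)C)C2=O)c1`: 1880 ug/mL

Both numbers come from a functional assay, with a stated time of 20 min; a higher number here means a weaker inhibitor, a lower number a stronger inhibitor. Among the compounds with values here, compound 2 has the lowest of the two numbers, with compound 1 as its only neighbour; the step of a 1.1-fold lower number from compound 1 to compound 2 (0.06 log units; within the scatter) is within the scatter, so the two compounds cannot be told apart on these data.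

The next compound in the series is compound 3, `CC(C)[C@@H]1CC[C@@H](C)C[C@@]12N(C)C(=O)[C@@H]1[C@H]3C(=O)N(c4ccc5ccccc5c4)C(=O)[C@H]3ON12`. It differs from compound 2 only on the aryl group carried by the ring amide nitrogen: naphthalen-2-yl in place of 3-methylphenyl on an amide-type nitrogen in a ring.

Within the data shown here, the only measured step that bears on this change is the earlier swap of one aryl group for another on the same nitrogen, a 1.1-fold lower number from compound 1 to compound 2 (0.06 log units; within the scatter), which stayed within the scatter. One step of this kind, of that size, gives no ground to expect a shift beyond the scatter in this assay for a further aryl swap; the expected step is therefore a 1.0-fold lower number from compound 2 to compound 3 (0.02 log units; within the scatter). On that basis compound 3 is estimated at 1800 ug/mL, with a range from 900 ug/mL to 3600 ug/mL.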

Compound 3, half-maximal inhibitory concentration: 2920 ug/mL
Beside the measured number, compound 3's estimate is 1.6-fold (0.21 log units) below it, and the stated range covers the measured number.
By their numbers in this assay, from the lowest: compounds 2, 1 and 3 (each within the scatter of the next).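

In this assay, a second six-membered aromatic ring of carbon only, added at the amide-type nitrogen in a ring, does not separate the new compound from the earlier two: naphthalen-2-yl in place of 3-methylphenyl gives a 1.6-fold higher number from compound 2 to compound 3 (0.19 log units; within the scatter), and naphthalen-2-yl in place of 4-chlorophenyl gives a 1.4-fold higher number from compound 1 to compound 3 (0.13 log units; within the scatter). Both steps lie within the scatter, so this position now has three aryl groups that cannot be told apart on these data, including one that enters with 10 heavy atoms against the 7 of 3-methylphenyl. No measured evidence is available that could explain these numbers or connect them to any property of the groups.

Still open, from the compounds shown here alone, is whether a group of another kind on this nitrogen, such as cyclohexyl or a longer alkyl chain, would move the number beyond the scatter in this assay. The same question stands for an aryl group carrying an amine or a carboxylic acid, since all three groups here have no hydrogen-bond donors or acceptors in the two entries counted and no net charge in those entries.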